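Fluorine on the phenyl ring of compound 2

The source may hold more compounds than are shown below. What is called first, only, known or untested is meant among the compounds shown, and "the series" means these compounds.

compound 1 `CC(C)(C)n1nc2c(c1-c1ccccc1)CCNCC2`: 30 nM
compound 2 `c1ccc(-c2c3c(nn2C2CCC2)CCNCC3)cc1`: 90 nM

Going by the values given here, in an assay on HEK293 cells for displacement of a labelled ligand from 5-hydroxytryptamine receptor 7 (Rattus norvegicus), read by radioligand binding (a lower number here means a stronger inhibitor, a higher number a weaker inhibitor), compound 2 holds the higher of the two numbers; compound 1 gives 30 nM, and the one measured step is a 3.0-fold higher number from compound 1 to compound 2 (0.48 log units; beyond the scatter). Compound 3 `Fc1ccc(-c2c3c(nn2C2CCC2)CCNCC3)cc1` differs from compound 2 by fluoro in place of hydrogen on an aromatic carbon, placed para to a large group. Among the compounds with values here, no measured step touches this ring: the known step concerns the group on the aromatic nitrogen and says nothing about fluoro in place of hydrogen. For compound 3 the expected step is therefore no change at the digits printed from compound 2 to compound 3 (within the scatter), not beyond the scatter, and the estimated value is 90 nM, ranging from 40 nM to 200 nM.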

Compound 3, inhibition constant: 150 nM
For compound 3 the middle estimate is 1.7-fold (0.22 log units) below the measured one; the measured number falls inside the stated range.
By their numbers in this assay, from the lowest: compound 1; then compounds 2 and 3 (each within the scatter of the next).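

On the phenyl ring, a place the earlier step did not touch, phenyl to 4-fluorophenyl gives a 1.7-fold higher number from compound 2 to compound 3 (0.22 log units; within the scatter) in this assay, so a fluoro para to a large group cannot be told apart from hydrogen here. Going by these compounds alone, this is the only reading at this position, and it holds for the cyclobutyl series alone. No supporting data bear on this result. Going by these compounds, whether a larger group such as methoxy or trifluoromethyl would behave the same at this place remains open. So does whether fluoro would read the same alongside the tert-butyl of compound 1.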